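Plasma protein binding across a shared core: compound 2 to compound 3

This account rests on a few compounds, and the source may have more. Where it says the series, first, only, none or still open, it means among the compounds named here.

Compound 1 `CCC(F)(F)c1nc2nc(C)cc(Nc3ccc(S(F)(F)(F)(F)F)cc3)n2n1` gives 97.7% in an ADME assay on a cell-free system (plasma, Homo sapiens) for protein binding.
Compound 2 `Cc1cc(Nc2ccc(S(F)(F)(F)(F)F)cc2)n2nc(C(C)(F)F)nc2n1` gives 97.4% in this assay.

Of the two measured compounds, compound 2 shows the highest unbound fraction in this assay, with compound 1 nearest: a 1.1-fold higher unbound fraction from compound 1 to compound 2 (0.05 log units; within the scatter). The two values therefore stand within the scatter of each other.

Compound 3 `COCCc1nc2nc(C)cc(Nc3ccc(S(F)(F)(F)(F)F)cc3)n2n1` has not yet been measured in this assay. It differs from compound 2 in one place: 2-methoxyethyl in place of 1,1-difluoroethyl on an aromatic carbon. Among the compounds with values here, the only measured step, from compound 1 to compound 2, concerns a hydrogen in place of a methyl on a saturated chain carbon and lies within the scatter; it does not bear directly on an exchange of a 1,1-difluoroethyl for a 2-methoxyethyl on an aromatic carbon. Within the data shown here, no measured step covers such a change, so there is no firm basis for a large expected step in either direction.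

Compound 3 is therefore expected to remain highly bound, estimated at 95.5% with a range from 91% to 98%. This estimate means a step of a 1.7-fold higher unbound fraction from compound 2 to compound 3 (0.24 log units; within the scatter), expected to lie close to the scatter.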

Compound 3, plasma protein binding in the plasma assay: 87.7%
Beside the measured number, compound 3's estimate is 2.7-fold (0.44 log units) (unbound fraction) below it, and the stated range ends above it.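

Within the data shown here, in the plasma assay the exchange on this aromatic carbon, between two ring nitrogen atoms, gives the first steps beyond the scatter: a 4.7-fold higher unbound fraction from compound 2 to compound 3 (0.67 log units; beyond the scatter), and a 5.3-fold higher unbound fraction from compound 1 to compound 3 (0.73 log units; beyond the scatter). The earlier change in the plasma assay, hydrogen in place of methyl on the saturated chain, stayed within the scatter at a 1.1-fold higher unbound fraction from compound 1 to compound 2 (0.05 log units; within the scatter), so it was replacing the whole 1,1-difluoroalkyl group with 2-methoxyethyl, rather than altering that chain, that first moved this read-out. In a physicochemical assay for solubility, at pH 6.5 (on this read-out lower numbers stand for lower solubility and higher numbers for higher solubility), compound 2 gives 30000 nM and compound 3 gives 31000 nM, with a 1.0-fold higher number from compound 2 to compound 3 (0.01 log units; within the scatter), so the two compounds that separate in the plasma assay stand within the scatter of each other on solubility.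

Nothing at hand accounts for the shift in binding. The exchange removes two fluorine atoms and brings in an oxygen in a single step, so the compounds shown leave open which of these goes with the step, and how a plain ethyl chain, a longer ether chain or an amine on this aromatic carbon would compare.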